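The source may hold more compounds than are shown below. What is called first, only, known or untested is meant among the compounds shown, and "the series" means these compounds.

Compound 1, `COc1ccc2c(c1)OC(c1cc(OC)c(OC)c(OC)c1)C(C(=O)NC(C)(C)C)=C2`, gives 28400 nM in a functional assay for inhibition of nuclear factor NF-kappa-B complex (Homo sapiens); on this read-out lower numbers stand for stronger inhibition and higher numbers for weaker inhibition.
Compound 2, `COc1ccc2c(c1)OC(c1cc(OC)c(OC)c(OC)c1)C(C(=O)N(C)OC)=C2`, gives 11700 nM in this assay.
Compound 3, `COC(=O)C1=Cc2ccc(OC)cc2OC1c1cc(OC)c(OC)c(OC)c1`, gives 13800 nM in this assay.

Compound 3 holds the second highest of the three numbers. The step of a 1.2-fold higher number from compound 2 to compound 3 (0.07 log units; within the scatter) lies within the scatter, whereas the step of a 2.1-fold lower number from compound 1 to compound 3 (0.31 log units; beyond the scatter) lies beyond it, so compound 3 is separated clearly only from compound 1.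

Compound 4, `COc1ccc2c(c1)OC(c1cc(OC)c(OC)c(OC)c1)C(C#N)=C2`, differs from compound 3 in one place: cyano in place of methoxycarbonyl on a double-bonded ring carbon. The measured steps all concern the group on a carbonyl carbon: a 2.4-fold lower number from compound 1 to compound 2 (0.39 log units; beyond the scatter) and a 2.1-fold lower number from compound 1 to compound 3 (0.31 log units; beyond the scatter) were modest, and a 1.2-fold higher number from compound 2 to compound 3 (0.07 log units; within the scatter) stayed within the scatter. Within the data shown here, none of them removes the carbonyl group itself or introduces a cyano group, so no measured step matches this change directly. Given that every variation at this position so far moved the number only modestly, a step of comparable size at most, in either direction, is expected, a 1.1-fold higher number from compound 3 to compound 4 (0.04 log units; within the scatter). Compound 4 is therefore estimated at 15000 nM in this assay, with a range from 5000 nM to 45000 nM.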

Compound 4, half-maximal inhibitory concentration: 3400 nM
Estimate against measurement, compound 4: 4.4-fold (0.64 log units) above; the whole stated range lies above it.
By their numbers in this assay, from the lowest: compound 4; then compounds 2 and 3 (each within the scatter of the next); then compound 1.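

In this assay, among these compounds, the earlier compounds varied only the group on a carbonyl carbon, whereas compound 4 replaces the whole carbonyl-bearing group on the double-bonded ring carbon with cyano. This change gives a 4.1-fold lower number from compound 3 to compound 4 (0.61 log units; beyond the scatter) and a 3.4-fold lower number from compound 2 to compound 4 (0.54 log units; beyond the scatter) and an 8.4-fold lower number from compound 1 to compound 4 (0.92 log units; beyond the scatter) at this position. Compound 4 therefore has the lowest number of the four, showing that this position can give a clear gain beyond the scatter over each carbonyl-bearing group shown.

On these data alone, how a carboxylic acid, a primary amide or a plain methyl group on this ring carbon would compare remains open. Also open, as far as these compounds go, is whether cyano keeps its lower number when the methoxy groups on the shared core are changed.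

Nothing at hand speaks to why cyano gives the lower number.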